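Swapping the benzoyl group for a methylindole amide

The source may hold more compounds than are shown below. What is called first, only, known or untested is meant among the compounds shown, and "the series" means these compounds.

Three amides of a shared threonine-derived core have been tested in a functional assay on HepG2 cells (Homo sapiens) for cytotoxicity, read by MTT assay, with a stated time of 48 h; a lower number here means a stronger inhibitor, a higher number a weaker inhibitor. Compound 1 `CCCCCCCCNC(=O)[C@@H](NC(=O)c1ccccc1)[C@@H](C)O` gives 136000 nM in this assay. Compound 2 `CCCCCCCCNC(=O)[C@@H](NC(=O)c1cc2ccccc2o1)[C@@H](C)O` gives 81300 nM in this assay. Compound 3 `CCCCCCCCCCCCNC(=O)[C@@H](NC(=O)c1ccccc1)[C@@H](C)O` reaches only a limit of the assay, > 400000 nM in this assay, so no exact number is known for it; it sits at the limit of > 400000 nM in this assay, at which 1 of the 3 values shown sits.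

For the measured compounds named here, two measured steps bear on the new compound. Going a 1.7-fold lower number from compound 1 to compound 2 (0.22 log units; within the scatter) shows that exchanging the benzoyl ring for a fused bicyclic one barely moved the reading. Going an at least 2.9-fold higher number from compound 1 to compound 3 (0.46 log units; beyond the scatter) shows that lengthening the chain weakened the effect.

Compound 4 `CCCCCCCCCCCCNC(=O)[C@@H](NC(=O)c1cc2ccccc2n1C)[C@@H](C)O` differs from compound 3 by 1-methyl-1H-indol-2-yl in place of phenyl on a carbonyl carbon. Since the comparable ring exchange from compound 1 to compound 2 stayed within the scatter, the expectation is that compound 4 also shows no step beyond the scatter, that is a step that the limit leaves unreadable from compound 3 to compound 4. Compound 4 is therefore estimated at 450000 nM in this assay, with a range from 150000 nM to 2000000 nM, and most likely it will again be reported only as a limit.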

Compound 4, half-maximal inhibitory concentration: > 200000 nM
Compound 4 ended at the assay's limit; the forecaster's own chance of this, stated with the estimate: 70%; the middle value does not contradict the limit.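

In this assay compound 4 gives > 200000 nM, which is a limit and not a number. Compound 3 also stands at a limit, > 400000 nM, so no step can be read between compound 3 and compound 4. Going by these compounds, whether 1-methyl-1H-indol-2-yl in place of phenyl changes the reading at all stays open: neither compound has an exact number.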